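Lengthening the methyl of compound 2 to 2-hydroxyethyl

This account rests on a few compounds, and the source may have more. Where it says the series, first, only, none or still open, it means among the compounds named here.

In a functional assay on SK-N-SH cells (Homo sapiens) for inhibition, read by MTT assay, with a stated time of 72 h, tested at 30 uM (a lower number here means less inhibition of growth, a higher number more inhibition of growth at the concentration tested), compound 1 (`C=CCc1ccc(OCc2cn(-c3cccc([N+](=O)[O-])c3)nn2)c(O)c1`) reaches 31.1% and compound 2 (`C=CCc1cc(O)c(O)c(CN2CCC(C)CC2)c1`) reaches 74.7% of growth inhibition. Compound 2 therefore stands highest of the two, and the gap lies beyond the usual scatter. Compound 3 (`C=CCc1cc(O)c(O)c(CN2CCC(CCO)CC2)c1`) differs from compound 2 by one change (hydroxymethyl in place of hydrogen on a saturated chain carbon bound to a saturated ring carbon): hydroxymethyl in place of hydrogen on a saturated chain carbon bound to a saturated ring carbon, which turns methyl into 2-hydroxyethyl. For the measured compounds named here, no measured pair shows this kind of change, so the forecast is tentative. The expected step is a number 12.7 percentage points lower from compound 2 to compound 3 (beyond the scatter) in this assay and points modestly downward. Compound 3 is expected at 62% within a range from 40% to 82% in this test.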

Compound 3, percent growth inhibition at one concentration: 15.3%
Estimate against measurement, compound 3: 46.7 percentage points above, outside the stated range (below it).
By their numbers in this assay, from the lowest: compound 3; then compound 1; then compound 2.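

Changing methyl to 2-hydroxyethyl, on a saturated chain carbon bound to a saturated ring carbon, gives a number 59.4 percentage points lower from compound 2 to compound 3 (beyond the scatter) in this assay. This single compound pair shows that growth inhibition here depends strongly on this position, and that adding only a hydroxymethyl can remove most of it. Nothing available explains the drop. From the compounds shown here alone, it remains open whether the loss follows the added length or the terminal hydroxyl. An ethyl or propyl chain, or a chain ending in an amine or a carboxylic acid, would help separate these possibilities.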